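The source may report more compounds than this note shows. Statements on the series, on what has been measured and on what is new or still open speak of the compounds shown alone.

Compound 1 `Cc1cc(C(=O)O)nn1Cc1cc(Br)ccc1OCc1ccccc1` carries a methyl group on its five-membered ring and, in an assay on CHO-K1 cells for displacement of a labelled ligand from prostaglandin E2 receptor EP1 subtype (Homo sapiens) (a higher number here means a weaker inhibitor, a lower number a stronger inhibitor), compound 1 gives 6.46 nM. Compound 2 `O=C(O)c1ccn(Cc2cc(Br)ccc2OCc2ccccc2)n1` has a hydrogen in place of that methyl, and in this assay compound 2 gives 9.77 nM. Going by the values given here, the one measured step, a 1.5-fold higher number from compound 1 to compound 2 (0.18 log units; within the scatter), shows that removing the methyl group left the number essentially unchanged, so compound 2 stands alongside compound 1 rather than apart from it, with only these two numbers known so far.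

Compound 3 `O=C(O)c1nn(Cc2cc(Br)ccc2OCc2ccccc2)cc1F` differs from compound 2 by fluoro in place of hydrogen on an aromatic carbon. Among the compounds with values here, no measured step changes a hydrogen on this ring to fluoro, so the only guide is that the one change already made on this ring, a 1.5-fold higher number from compound 1 to compound 2 (0.18 log units; within the scatter), stayed within the scatter. On that basis the step is expected to be small, and a step of a 1.2-fold higher number from compound 2 to compound 3 (0.09 log units; within the scatter) in this assay is estimated, in either direction no further than the scatter allows. Compound 3 is therefore expected to give about 12 nM in this assay, with a likely range from 4 nM to 35 nM.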

Compound 3, half-maximal inhibitory concentration: 123 nM
Compound 3: middle estimate off by 10-fold (1.01 log units), on the low side; the whole stated range lies below it.
By their numbers in this assay, from the lowest: compounds 1 and 2 (each within the scatter of the next); then compound 3.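

Going by these compounds alone, this is the first change that moves the number beyond the scatter: in this assay the step is a 13-fold higher number from compound 2 to compound 3 (1.10 log units; beyond the scatter) and stands apart from a 1.5-fold higher number from compound 1 to compound 2 (0.18 log units; within the scatter) which stayed within it. It shows that a single fluoro in place of hydrogen, on the aromatic carbon next to the ring atom that bears a carboxy group, is enough to make this compound a clearly weaker inhibitor than its parent, even though only one heavy atom enters. So among these three compounds, a small change on the five-membered ring does not always leave the number unchanged, and nothing measured here accounts for the size of this step.

The compounds shown leave open whether a chloro or a methoxy group on this same carbon would raise the number as far, or whether hydrogen alone keeps it low here. They also leave open whether fluoro on the ring carbon that carries the methyl in compound 1 would give a step of similar size, which would show whether the loss belongs to this position or to fluoro anywhere on the ring.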